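The source may hold more compounds than are shown below. What is called first, only, known or untested is meant among the compounds shown, and "the series" means these compounds.

Working notes on the naphthamide series at the dopamine receptor.

Three compounds share one core and differ only in the group on the benzyl ring. Compound 1 `O=C(NC1CCN(Cc2cccc(Br)c2)CC1)c1cccc2ccccc12` carries bromo there; in an assay on isolated protein for displacement of a labelled ligand from D(4) dopamine receptor (Homo sapiens) (on this read-out lower numbers stand for stronger inhibition and higher numbers for weaker inhibition), compound 1 gives 66 nM. Compound 2 `O=C(NC1CCN(Cc2cccc(C(F)(F)F)c2)CC1)c1cccc2ccccc12` carries trifluoromethyl and in this assay compound 2 gives 119 nM. Compound 3 `COc1cccc(CN2CCC(NC(=O)c3cccc4ccccc34)CC2)c1` carries methoxy, and in this assay compound 3 gives 168 nM. Compound 1 thus holds the lowest of the three numbers; the step of a 1.8-fold higher number from compound 1 to compound 2 (0.26 log units; within the scatter) stays within the scatter, while the step of a 2.5-fold higher number from compound 1 to compound 3 (0.41 log units; beyond the scatter) just passes it. Between the other two, the step of a 1.4-fold higher number from compound 2 to compound 3 (0.15 log units; within the scatter) is within the scatter.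

Compound 4 `Cc1cccc(CN2CCC(NC(=O)c3cccc4ccccc34)CC2)c1` is the next member: methyl in place of bromo on an aromatic carbon. The bearing steps are those away from bromo: a 1.8-fold higher number from compound 1 to compound 2 (0.26 log units; within the scatter) and a 2.5-fold higher number from compound 1 to compound 3 (0.41 log units; beyond the scatter), both leading to higher numbers, one small and one modest. Neither replacement is methyl, so the series gives no direct reading for it. The expectation is a step of a 1.5-fold higher number from compound 1 to compound 4 (0.18 log units; within the scatter) in this assay, towards a higher number but not beyond the scatter. For compound 4 the estimate in this assay is 100 nM, with a likely range from 40 nM to 250 nM.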

Compound 4, inhibition constant: 77 nM
Beside the measured number, compound 4's estimate is 1.3-fold (0.11 log units) above it, and the stated range covers the measured number.
By their numbers in this assay, from the lowest: compounds 1, 4, 2 and 3 (each within the scatter of the next, the first and the last beyond it).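

Methyl in place of bromo, the 3-bromobenzyl to 3-methylbenzyl change, gives a 1.2-fold higher number from compound 1 to compound 4 (0.07 log units; within the scatter) in this assay, so this assay does not separate these two groups on this aromatic carbon. Methyl in place of trifluoromethyl gives a 1.5-fold lower number from compound 2 to compound 4 (0.19 log units; within the scatter) and likewise brings no separation, while methyl in place of methoxy gives a 2.2-fold lower number from compound 3 to compound 4 (0.34 log units; beyond the scatter), which leaves methoxy set apart from both bromo and methyl by more than the scatter, with trifluoromethyl within the scatter of all three. The separation of methoxy from bromo thus gains a second reading with methyl, but nothing at hand accounts for any of these steps.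

From the compounds shown here alone, the four compounds cover only bromo, trifluoromethyl, methoxy and methyl at this place, so the reading for plain hydrogen, an amine, a carboxylic acid or a longer chain such as ethoxy stays open. Going by these compounds, whether the same groups would read alike on the other carbons of that ring, or with the rest of the shared core changed, also stays open.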